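This account rests on a few compounds, and the source may have more. Where it says the series, first, only, none or still open, it means among the compounds named here.

Measured so far:
Compound 1, `COc1cc(NC(=O)c2ccc(C#N)cc2)ccc1NS(C)(=O)=O`, gives > 250000 nM in an ADME assay on HEK293 cells (Homo sapiens) for cytotoxicity, read by MTT assay, with a stated time of 48 h (a higher number here means a weaker inhibitor, a lower number a stronger inhibitor), which is a limit of the assay rather than a number.
Compound 2, `CS(=O)(=O)Nc1ccc(NC(=O)c2ccc(Cl)cc2)cc1F`, gives 216000 nM in this assay .

For the measured compounds named here, compound 2 therefore stands at the only actual number in this small set; the one other value sits at the limit of > 250000 nM in this assay, at which 1 of the 2 values shown sits, so there is no measured step to compare it with. Both compounds share the same core, an amide linking a sulfonamide-bearing ring to a para-substituted benzoyl group, and both inhibit the cells only very weakly.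

The next compound, compound 3, `CS(=O)(=O)Nc1ccc(NC(=O)c2ccc(C#N)cc2)cc1F`, keeps the fluoro-bearing ring of compound 2 and changes only the benzoyl substituent: cyano in place of chloro on an aromatic carbon, para to a large group. Going by the values given here, since no step between measured compounds exists to guide the size of this change, the expectation in this assay is no shift beyond the usual scatter, and a fair chance that the assay again returns only a limit.

Compound 3 is expected to give 230000 nM in this assay , with a range from 110000 nM to 300000 nM. The step this estimate means is expected to be a 1.1-fold higher number from compound 2 to compound 3 (0.03 log units; within the scatter).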

Compound 3, half-maximal inhibitory concentration: > 250000 nM
Compound 3: only a limit was reported; the forecaster's own chance of this, stated with the estimate: 45%; middle value at least 1.0-fold (0.03 log units) away from the limit.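

In this assay, putting cyano in place of chloro on an aromatic carbon, para to a large group, gives an at least 1.1-fold higher number from compound 2 to compound 3 (0.06 log units; that floor lies within the scatter). For the compounds shown here, this is the first step that can be sized at all in this set, yet only its lower bound is known, and the real distance between the two compounds could be small or much larger. The step from compound 1 to compound 3, with fluoro in place of methoxy on an aromatic carbon, cannot be read, and the result for compound 3 is a limit rather than a number, which adds to the values of this kind: the limit of > 250000 nM in this assay, at which 2 of the 3 values shown sit.

From the compounds shown here alone, it remains open whether a different group at this place on the benzoyl ring, such as an amine or a carboxylic acid, would shift the reading clearly beyond the scatter. The effect of the fluoro or methoxy group on the other ring also stays unresolved, and settling it would take a compound pair in which both readings are actual numbers.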